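Notes on hydroxy-to-hydrogen steps across four compounds

The source may hold more compounds than are shown below. What is called first, only, known or untested is meant among the compounds shown, and "the series" means these compounds.

Compound 1 `O=C1c2c(O)cc(O)cc2O[C@H](c2c(O)cccc2O)[C@H]1O` gives in a physicochemical assay, read by spectrophotometry, with a stated time of 30 min (on this read-out higher numbers stand for an effect only at larger amounts of compound and lower numbers for an effect already at smaller amounts), only > 100000 nM, which is a limit of the assay and not a number. Compound 3 `O=C1c2c(O)cc(O)cc2O[C@H](c2ccccc2O)[C@H]1O` likewise gives > 100000 nM, again a limit. The change hydrogen in place of hydroxy on an aromatic carbon therefore yields a step that the two limits leave unreadable from compound 1 to compound 3, as all measured values sit at the limit of > 100000 nM in this assay, at which 3 of the 3 values shown sit. Compound 2 `O=C1c2c(O)cc(O)cc2O[C@@H](c2cc(O)cc(O)c2)[C@@H]1O` has the same atoms as compound 1 joined differently; the difference between the two cores is not broken down here. In this assay compound 2 gives > 100000 nM, a limit. Compound 4 `O=C1c2c(O)cc(O)cc2O[C@@H](c2cccc(O)c2)[C@@H]1O` is not yet measured and differs from compound 2 by hydrogen in place of hydroxy on an aromatic carbon, the same kind of change as from compound 1 to compound 3, though here the place is meta to a large group rather than ortho to a large group. For compound 4 a value of 150000 nM is expected, most probably again a limit. The estimated step is a step that the limit leaves unreadable from compound 2 to compound 4.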

Compound 4, half-maximal effective concentration: > 100000 nM
Compound 4: only a limit was reported; the forecaster's own chance of this, stated with the estimate: 85%; the middle value lies beyond the limit too.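

No step can be read between compound 2 and compound 4, because both give only a limit and not a number: the limit of > 100000 nM in this assay, at which 4 of the 4 values shown sit.

The compounds shown leave open whether hydrogen in place of hydroxy on an aromatic carbon changes the read-out at all, and how the two cores compare.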